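This account rests on a few compounds, and the source may have more. Where it says the series, first, only, none or still open, it means among the compounds named here.

Compound 1: `Cn1c(-c2cc(-c3ccccc3)no2)cc(Br)c1Br`; in a functional assay on MCF7 cells (Homo sapiens) for cytotoxicity, read by MTT assay, with stated times of 6 h and 48 h (on this read-out higher numbers stand for weaker inhibition and lower numbers for stronger inhibition), compound 1 gives >= 100000 nM, which is a limit of the assay and not a number.
Compound 2: `Cn1c(-c2cc(-c3ccc[nH]3)no2)cc(Br)c1Br`; in this assay compound 2 gives >= 100000 nM, which is also a limit of the assay.

Compound 2 therefore stands at the edge of what this assay reports: the limit of >= 100000 nM in this assay, at which 2 of the 2 values shown sit. For the measured compounds named here, the only measured step, a step that the two limits leave unreadable from compound 1 to compound 2, cannot be read because both ends are limits.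

Compound 3 is `Brc1cc(-c2cc(-c3ccc[nH]3)no2)[nH]c1Br`. It differs from compound 2 by hydrogen in place of methyl on an aromatic nitrogen. Going by the values given here, no measured step involves a change of this kind, and the one step that exists, a step that the two limits leave unreadable from compound 1 to compound 2, has no readable size, so nothing measured points in either direction.

Compound 3 is therefore expected to sit where compound 2 sits, with an estimated value of 100000 nM and a range from 30000 nM to 300000 nM. The step of a number no higher from compound 2 to compound 3 (the limit leaves the size open) is expected to be within the scatter, and most likely the assay will again report only a limit.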

Compound 3, half-maximal inhibitory concentration: >= 100000 nM
Compound 3 gave a limit, no number; the forecaster's own chance of this, stated with the estimate: 85%; the middle value sits exactly at the limit.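

Compound 2 and compound 3 both give a limit of the assay and not a number, so the step between them cannot be read. All the compounds shown stand at the same edge: the limit of >= 100000 nM in this assay, at which 3 of the 3 values shown sit.

What the compounds shown leave open is how far any of them truly differ in this assay.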